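Compound 3: benzyl in place of 3,4-dihydroxyphenyl

This account rests on a few compounds, and the source may have more. Where it says the series, first, only, none or still open, it means among the compounds named here.

In a functional assay on HeLa cells (Homo sapiens) for inhibition, read by CCK-8 assay, with a stated time of 48 h (a lower number here means a stronger inhibitor, a higher number a weaker inhibitor), compound 1 `Nc1ccc(Oc2ccccc2-c2ccc(S(=O)(=O)NCCNC(=O)Nc3cc(C(F)(F)F)cc(C(F)(F)F)c3)s2)cc1` gives > 20000 nM, which is a limit of the assay and not a number. Compound 2 `O=C(NCCNS(=O)(=O)c1ccc(-c2ccccc2Oc2ccc(O)c(O)c2)s1)Nc1cc(C(F)(F)F)cc(C(F)(F)F)c1` gives > 20000 nM, also a limit. For the measured compounds named here, the series so far therefore stands at the limit of > 20000 nM in this assay, at which 2 of the 2 values shown sit.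

Compound 3 `O=C(NCCNS(=O)(=O)c1ccc(-c2ccccc2OCc2ccccc2)s1)Nc1cc(C(F)(F)F)cc(C(F)(F)F)c1` differs from compound 2 in one place: benzyl in place of 3,4-dihydroxyphenyl on an oxygen on an aromatic ring. The same difference, cut one bond further out, reads 3,4-dihydroxyphenoxy to benzyloxy.

Going by the values given here, the only measured step bearing on this change is a step that the two limits leave unreadable from compound 1 to compound 2, which also falls on an oxygen on an aromatic ring. Among the compounds with values here, it offers no size to carry over, so no step of known size or direction is expected in this assay. The estimated change is a number no higher from compound 2 to compound 3 (the limit leaves the size open). The expected value for compound 3 is 20000 nM, with an estimated range of 7000 nM to 60000 nM.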

Compound 3, half-maximal inhibitory concentration: 13500 nM
Compound 3: the middle estimate sits 1.5-fold (0.17 log units) above what was measured; low and high end bracket the measured number.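

In this assay compound 3 gives 13500 nM as a number and not a limit, which makes benzyl the only group shown on this oxygen with a readable value. As far as these compounds go, the change reads as an at least 1.4-fold lower number from compound 2 to compound 3 (0.17 log units; that floor lies within the scatter) and as an at least 1.4-fold lower number from compound 1 to compound 3 (0.17 log units; that floor lies within the scatter) and each of these is only a floor, so the true size of the change stays open and no gain can be claimed from it. The step from compound 1 to compound 2 cannot be read, and both of those compounds remain at a limit of the assay: the limit of > 20000 nM in this assay, at which 2 of the 3 values shown sit.

From the compounds shown here alone, whether the value depends on the benzyl ring itself or on the absence of the hydroxyl groups stays open. A plain phenyl, a methyl, a longer chain such as phenethyl, or a benzyl carrying an amine or a carboxylic acid would bear on that question.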